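Trimming the side chain on a shared core

The compounds below may be only part of what the source reports. "The series", "measured", "known", "first", "only" and "open" are said of these compounds alone.

Three compounds have been measured in a functional assay on J774.A1 cells (Mus musculus) for inhibition, read by Griess assay, with stated times of 1 h and 24 h; on this read-out lower numbers stand for stronger inhibition and higher numbers for weaker inhibition:

Compound 1 `CC(C)c1ccc(COc2ccccc2C2CC(=O)c3ccccc3O2)cc1`: 28600 nM
Compound 2 `COCOc1ccccc1C1CC(=O)c2ccccc2O1`: 35200 nM
Compound 3 `CCCOc1ccccc1C1CC(=O)c2ccccc2O1`: 44600 nM

Compound 2 sits in the middle of this small set, and all three numbers lie close together: one step is a 1.2-fold higher number from compound 1 to compound 2 (0.09 log units; within the scatter), and the other is a 1.3-fold higher number from compound 2 to compound 3 (0.10 log units; within the scatter). Compound 4 `COc1ccccc1C1CC(=O)c2ccccc2O1` is the next step from compound 2, with this change: hydrogen in place of methoxy on a saturated chain carbon bound to an oxygen on an aromatic ring. The steps already seen at this same place, a 1.2-fold higher number from compound 1 to compound 2 (0.09 log units; within the scatter), a 1.3-fold higher number from compound 2 to compound 3 (0.10 log units; within the scatter) and a 1.6-fold higher number from compound 1 to compound 3 (0.19 log units; within the scatter), all stayed within the scatter, so no change beyond the scatter is expected here either. Compound 4 is therefore estimated at 40000 nM, within 15000 nM to 100000 nM, meaning an expected step of a 1.1-fold higher number from compound 2 to compound 4 (0.06 log units; within the scatter).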

Compound 4, half-maximal inhibitory concentration: 44500 nM
Beside the measured number, compound 4's estimate is 1.1-fold (0.05 log units) below it; the measured number falls inside the stated range.
By their numbers in this assay, from the lowest: compounds 1, 2, 4 and 3 (each within the scatter of the next).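

Cutting methoxymethoxy down to methoxy leaves the number in this assay within the scatter (a 1.3-fold higher number from compound 2 to compound 4 (0.10 log units; within the scatter)). Hydrogen in place of ethyl (a 1.0-fold lower number from compound 3 to compound 4 (0.00 log units; within the scatter)) and in place of 4-isopropylphenyl (a 1.6-fold higher number from compound 1 to compound 4 (0.19 log units; within the scatter)) also stays within the scatter, so in these four compounds even the plain methoxy, with no further chain on it, reads no differently from the largest group shown. Nothing on hand explains this flat result.

Still open, going by these compounds, is whether a group of another kind at this place, such as an amine or a carboxylic acid, would move the number beyond the scatter. Changes elsewhere on the shared core also remain untested in these compounds.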